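This account rests on a few compounds, and the source may have more. Where it says the series, first, only, none or still open, it means among the compounds named here.

Measured in an in vitro assay on HEK385-7 cells for displacement of a labelled ligand from prostaglandin D2 receptor 2 (Homo sapiens); on this read-out lower numbers stand for stronger inhibition and higher numbers for weaker inhibition:
compound 1 `Nc1nc(-c2ccc(Cl)cc2)c(CC(=O)O)s1` — this assay > 100000 nM (a limit of the assay, not a number)
compound 2 `O=C(O)Cc1sc(Cc2ccccc2-c2ccccc2)nc1-c1ccc(Cl)cc1` — this assay 41 nM
compound 3 `CS(=O)(=O)Nc1cccc(-c2nc(C(c3ccc(F)cc3)c3ccc(F)cc3)sc2CC(=O)O)c1` — this assay 40 nM

Compound 1 sits at a limit of the assay the limit of > 100000 nM in this assay, at which 1 of the 3 values shown sits, and gives no number. For the measured compounds named here, compound 3 and compound 2 give numbers within the usual scatter of each other, so neither can be set above the other; compound 3 thus stands level with the only other numbered value in the set. Going by the values given here, no step between measured compounds differs in a single place, so the change to compound 4 `O=C(O)Cc1sc(C(c2ccc(F)cc2)c2ccc(F)cc2)nc1-c1ccnc(N2CCC2)c1` is read without a measured precedent.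

Compound 4 differs from compound 3 as follows: 2-(azetidin-1-yl)pyridin-4-yl in place of 3-(methanesulfonamido)phenyl on an aromatic carbon. The diaryl methyl group and the carboxymethyl group on the shared core are kept. The step from compound 3 to compound 4 is expected to be small, with a slight drift toward weaker binding that may not exceed the scatter, a 1.8-fold higher number from compound 3 to compound 4 (0.24 log units; within the scatter). For compound 4 in this assay the estimate is 70 nM, within a range from 20 nM to 300 nM.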

Compound 4, half-maximal inhibitory concentration: 660 nM
Beside the measured number, compound 4's estimate is 9.4-fold (0.97 log units) below it, outside the stated range (above it).
By their numbers in this assay, from the lowest: compounds 3 and 2 (each within the scatter of the next); then compound 4. At a limit, above all of these: compound 1.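

In this assay, for the compounds shown here, the swap of 3-(methanesulfonamido)phenyl for 2-(azetidin-1-yl)pyridin-4-yl gives a 17-fold higher number from compound 3 to compound 4 (1.22 log units; beyond the scatter) and is the first change in this set confined to one place. With the diaryl methyl group and the carboxymethyl group kept, the aromatic carbon next to the ring nitrogen and next to the ring atom bearing the carboxymethyl group is therefore shown to be sensitive to the group it carries, though the ring, the substituent and the hydrogen-bond donor count all change together in this one step. No measured evidence here bears on the reason for this loss.

Which part of the swap carries the loss remains open. An unsubstituted phenyl, or an acetamido group in place of the methanesulfonamido group, at this carbon would help to separate the contributions of the ring and its substituent.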